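The compounds below may be only part of what the source reports. "The series", "measured", "known", "first", "only" and "open" are said of these compounds alone.

Three compounds share one core carrying two aryl rings. Compound 1 `O=[N+]([O-])c1cccc(-c2cc(-c3ccccc3)n[nH]2)c1` gives 5800 nM in a functional assay on OVCAR cells (Homo sapiens) for inhibition, read by MTT assay, with a stated time of 48 h; a lower number here means a stronger inhibitor of growth, a higher number a weaker inhibitor of growth; in this assay compound 2 `COc1ccccc1-c1cc(-c2ccc([N+](=O)[O-])cc2)[nH]n1` gives 11700 nM and compound 3 `Nc1ccc(-c2cc(-c3ccc(C(F)(F)F)cc3)n[nH]2)cc1` gives 18600 nM. Compound 3 has the highest number of the three: its gap to compound 2 is within the scatter, while its gap to compound 1 lies beyond it. Compound 4 `Oc1ccc(-c2cc(-c3ccc(C(F)(F)F)cc3)n[nH]2)cc1` differs from compound 3 by hydroxy in place of amino on an aromatic carbon. Going by the values given here, no measured pair shows this exchange, so nothing fixes its direction; the expected step is a 1.2-fold lower number from compound 3 to compound 4 (0.09 log units; within the scatter), not beyond the scatter. Compound 4 is therefore expected to give 15000 nM in this assay, between 6000 nM and 40000 nM.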

Compound 4, concentration for 50% growth inhibition: 9200 nM
Beside the measured number, compound 4's estimate is 1.6-fold (0.21 log units) above it; the range from low to high includes it.
By their numbers in this assay, from the lowest: compounds 1, 4, 2 and 3 (each within the scatter of the next, the first and the last beyond it).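

Hydroxy in place of amino, on an aromatic carbon para to a large group, gives the first single-place step in this set: a 2.0-fold lower number from compound 3 to compound 4 (0.31 log units; beyond the scatter) in this assay. This position therefore responds to the exchange, although the two groups match in hydrogen-bond donors and acceptors and neither carries a net charge. Nothing available accounts for the step.

As far as these compounds go, whether a carboxylic acid or a methoxy group at this position would go further in the same direction stays open. So does whether the step holds when the trifluoromethyl group on the other ring is replaced.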